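A few compounds are considered here, and "the series" means these few. Any claim that something is new, unique, unknown or untested is made for them only; others in the source may bear on it.

Of the compounds shown here, two sharing one core have been measured in an ADME assay on A549 cells (Homo sapiens) for cytotoxicity, with a stated time of 72 h; on this read-out higher numbers stand for weaker inhibition and lower numbers for stronger inhibition. Compound 1 `COc1cc(NC(C)CCCN2C(=O)CN(C(=O)[C@H](N)CC(C)C)C2(C)C)c2ncccc2c1` carries a 1-amino-3-methylbutyl group on a carbonyl carbon, and in this assay compound 1 gives 21200 nM. Compound 2 `COc1cc(NC(C)CCCN2C(=O)CN(C(C)=O)C2(C)C)c2ncccc2c1` carries a methyl group in that place instead. For compound 2 this assay reports only a limit, > 100000 nM. The measured step of an at least 4.7-fold higher number from compound 1 to compound 2 (0.67 log units; beyond the scatter) therefore gives only a lower bound on how much that exchange weakened the read-out, as the value sits at the limit of > 100000 nM in this assay, at which 1 of the 2 values shown sits. Compound 3 `COc1cc(NC(C)CCCN2C(=O)CN(C(=O)[C@H](N)C(C)C)C2(C)C)c2ncccc2c1` has not yet been measured; compared with compound 2 the change is 1-amino-2-methylpropyl in place of methyl on a carbonyl carbon. Within the data shown here, this runs opposite to the measured step, restoring an amino-bearing branched group closely related to the one in compound 1. Because taking such a group away produced an at least 4.7-fold higher number from compound 1 to compound 2 (0.67 log units; beyond the scatter), putting a similar group back is expected to lower the number by about the same amount, so the expected step is an at least 4.0-fold lower number from compound 2 to compound 3 (0.60 log units; beyond the scatter). Compound 3 is therefore estimated to give 25000 nM, with a likely range from 8000 nM to 100000 nM.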

Compound 3, half-maximal inhibitory concentration: 5500 nM
For compound 3 the middle estimate is 4.5-fold (0.66 log units) above the measured one, outside the stated range (below it).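

In this assay, among these compounds, replacing methyl with 1-amino-2-methylpropyl on a carbonyl carbon gives an at least 18-fold lower number from compound 2 to compound 3 (1.25 log units; beyond the scatter), so the lower number seen with compound 1 is not tied to the single group it carries. For compound 2 the value is a limit and not a number, which makes the size of this step a lower bound: the limit of > 100000 nM in this assay, at which 1 of the 3 values shown sits. The new compound also shows that the choice of amino-bearing group matters, and not only its presence: isopropyl in place of isobutyl on the saturated chain carbon bound to an amine nitrogen and a carbonyl carbon gives a 3.9-fold lower number from compound 1 to compound 3 (0.59 log units; beyond the scatter).

The compounds shown do not separate the contribution of the amine from that of the branched chain, a question that a plain aminomethyl group, or an isobutyl group with no amine, could help to answer. As far as these compounds go, it also remains open whether the trend from isobutyl to isopropyl continues with a smaller chain such as ethyl, and what the opposite configuration at the defined stereocentre would give.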